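The compounds below may be only part of what the source reports. "The series", "measured", "known", "first", "only" and "open" are said of these compounds alone.

Measured so far:
Compound 1, `Cc1ccc(-c2nnc(N3CCN(C(=O)CN4CCN(c5ccccc5)CC4)CC3)nc2-c2ccc(C)cc2)cc1`, gives 914000 nM in a functional assay on MCF7 cells (Homo sapiens) for cytotoxicity, read by MTT assay, with a stated time of 24 h; on this read-out higher numbers stand for weaker inhibition and lower numbers for stronger inhibition.
Compound 2, `Cc1ccc(-c2nnc(N3CCN(C(=O)CN4CCN(c5cccc(Cl)c5)CC4)CC3)nc2-c2ccc(C)cc2)cc1`, gives 797000 nM in this assay.

Both compounds share one core and differ only in a substituent on the outer phenyl ring attached to a piperazine nitrogen: compound 1 carries a plain phenyl, compound 2 a chloro on that ring. The step of a 1.1-fold lower number from compound 1 to compound 2 (0.06 log units; within the scatter) lies within the usual scatter, so the two compounds cannot be told apart on the numbers shown; compound 2 has the smaller of the two numbers, but that gap carries no weight.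

Compound 3, `COc1ccc(N2CCN(CC(=O)N3CCN(c4nnc(-c5ccc(C)cc5)c(-c5ccc(C)cc5)n4)CC3)CC2)cc1`, is the next member of this set. It differs from compound 2 in one place: 4-methoxyphenyl in place of 3-chlorophenyl on an amine nitrogen in a ring. Among the compounds with values here, no measured step covers this change. Within the data shown here, the only step at hand, from hydrogen to chloro on the same ring, was within the scatter, and there is nothing to suggest the methoxy group would behave differently. The expectation for compound 3 is therefore no step beyond the scatter, with a 1.1-fold higher number from compound 2 to compound 3 (0.03 log units; within the scatter). The estimate for compound 3 in this assay is 850000 nM, with a range from 400000 nM to 1800000 nM.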

Compound 3, half-maximal inhibitory concentration: 53000 nM
Estimate against measurement, compound 3: 16-fold (1.21 log units) above; the measured number lies below the stated range.
By their numbers in this assay, from the lowest: compound 3; then compounds 2 and 1 (each within the scatter of the next).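

In this assay, the aromatic ring on the amine nitrogen turns out to matter: replacing 3-chlorophenyl with 4-methoxyphenyl gives a 15-fold lower number from compound 2 to compound 3 (1.18 log units; beyond the scatter). Measured against the plain phenyl, methoxy in place of hydrogen gives a 17-fold lower number from compound 1 to compound 3 (1.24 log units; beyond the scatter), whereas chloro in place of hydrogen gave only a 1.1-fold lower number from compound 1 to compound 2 (0.06 log units; within the scatter), so a substituent on this ring is not always without effect, as the first pair alone might have suggested. Nothing available here explains why the two substituents differ so much.

Compound 3 differs from compound 2 in both the substituent and its numbered place on the ring, so these compounds cannot show whether the stronger inhibition follows the methoxy group itself or the 4-position. A 3-methoxyphenyl or a 4-chlorophenyl group would separate those two possibilities, and a 4-ethoxyphenyl or 4-hydroxyphenyl group would show whether the effect survives a change to the oxygen substituent.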